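Thiazolyl for methoxymethyl on the aryl ring

A few compounds are considered here, and "the series" means these few. Any claim that something is new, unique, unknown or untested is made for them only; others in the source may bear on it.

Compound 3 `COCc1cccc(C(=O)N2CCCC(C(=O)Nc3ccc(Cl)cc3)C2)c1` gives 0% in an ADME assay on PC-3 cells (Homo sapiens) for cytotoxicity, read by WST assay, tested at 100 uM (a lower number here means less inhibition, a higher number more inhibition at the concentration tested (going by the name of the read-out)), and stands level with compound 2 `C=Cc1cccc(C(=O)N2CCCC(C(=O)Nc3ccc(Cl)cc3)C2)c1`, which gives 0%; together they are the lowest of the three measured numbers. Compound 1 `O=C(Nc1ccc(Cl)cc1)C1CCCN(C(=O)c2cccc(-c3nccs3)c2)C1`, carrying 1,3-thiazol-2-yl, gives 32%, and the step of a number 32 percentage points lower from compound 1 to compound 3 (beyond the scatter) is the only one that bears on a thiazolyl exchange here; the step of no change at the digits printed from compound 2 to compound 3 (within the scatter) shows the two non-ring groups behaving alike. Compound 4 `Cc1nc(-c2cccc(C(=O)N3CCCC(C(=O)Nc4ccc(Cl)cc4)C3)c2)cs1` differs from compound 3 by 2-methyl-1,3-thiazol-4-yl in place of methoxymethyl on an aromatic carbon. Since the loss of a thiazolyl gave a large drop due to a number 32 percentage points lower from compound 1 to compound 3 (beyond the scatter), a rise of moderate size is expected for compound 4, though the ring attaches at a different position and carries a methyl. Compound 4 is estimated at 20%, between 0% and 45%, a step of a number 20 percentage points higher from compound 3 to compound 4 (beyond the scatter) expected from compound 3.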

Compound 4, a percentage reported as inhibition, at one concentration (the size of the read-out at that concentration, not a potency): 1%
Beside the measured number, compound 4's estimate is 19 percentage points above it; the range from low to high includes it.
By their numbers in this assay, from the lowest: compounds 2, 3 and 4 (each within the scatter of the next); then compound 1.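

In this assay, a thiazole ring at this place does not by itself give a higher number: a number 1 percentage points higher from compound 3 to compound 4 (within the scatter) and a number 1 percentage points higher from compound 2 to compound 4 (within the scatter), which puts 2-methyl-1,3-thiazol-4-yl level with methoxymethyl and vinyl. The exchange of one thiazolyl group for the other matters instead, a number 31 percentage points lower from compound 1 to compound 4 (beyond the scatter), so among these four compounds only compound 1, with 1,3-thiazol-2-yl, stands apart. Nothing at hand explains this difference between the two thiazolyl groups.

Still open, as far as these compounds go, is whether the methyl or the point of attachment separates compound 4 from compound 1, which a plain 1,3-thiazol-4-yl would help to settle. From the compounds shown here alone, how an aminomethyl group or a carboxylic acid would read at this place also remains open.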